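A Fused Thiophene Replaces the Bromophenyl Ring

The source may hold more compounds than are shown below. What is called first, only, known or untested is meant among the compounds shown, and "the series" means these compounds.

Of the compounds shown here, three built on a shared core have been measured in a functional assay on Jurkat cells for inhibition of nuclear factor NF-kappa-B complex (Homo sapiens); on this read-out lower numbers stand for stronger inhibition and higher numbers for weaker inhibition. Compound 1 `CCOC(=O)c1cnc(-c2cccs2)nc1NN1C(=O)C=C(C)C1=O` gives 20 nM, compound 2 `CCOC(=O)c1cnc(-c2cc(Cl)nc(Cl)c2)nc1NN1C(=O)C=C(C)C1=O` gives 2000 nM, and compound 3 `CCOC(=O)c1cnc(-c2cccc(Br)c2)nc1NN1C(=O)C=C(C)C1=O` gives 700 nM. Among these three numbers compound 3 stands second highest: its nearest neighbour is compound 2, with a 2.9-fold lower number from compound 2 to compound 3 (0.46 log units; beyond the scatter), and its furthest is compound 1, with a 35-fold higher number from compound 1 to compound 3 (1.54 log units; beyond the scatter). Compound 4 `CCOC(=O)c1cnc(-c2cc3ccccc3s2)nc1NN1C(=O)C=C(C)C1=O` has not yet been measured in this assay. It differs from compound 3 in one place: 1-benzothiophen-2-yl in place of 3-bromophenyl on an aromatic carbon. Among the measured compounds shown here, two measured steps bear on this change. The step of a 35-fold higher number from compound 1 to compound 3 (1.54 log units; beyond the scatter) shows that exchanging thiophen-2-yl for 3-bromophenyl raised the number strongly, and the step of a 100-fold higher number from compound 1 to compound 2 (2.00 log units; beyond the scatter) shows that 2,6-dichloropyridin-4-yl raised it further still. Compound 4 brings back a five-membered aromatic ring with one hetero atom, now joined to a six-membered aromatic ring of carbon only. Since compound 1 with its thiophen-2-yl group gives 20 nM, compound 4 is expected to move a large part of the way back toward that number, a step of a 12-fold lower number from compound 3 to compound 4 (1.07 log units; beyond the scatter). Compound 4 is therefore estimated at 60 nM, within a range from 15 nM to 250 nM.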

Compound 4, half-maximal inhibitory concentration: 4000 nM
Compound 4: the middle estimate sits 67-fold (1.82 log units) below what was measured; the whole stated range lies below it.
By their numbers in this assay, from the lowest: compound 1; then compound 3; then compounds 2 and 4 (each within the scatter of the next).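

At this position on the shared core, a five-membered aromatic ring with one hetero atom does not by itself bring the low number back: in this assay the fused group gives a 200-fold higher number from compound 1 to compound 4 (2.30 log units; beyond the scatter) in a comparison with thiophen-2-yl. Exchanging 3-bromophenyl for 1-benzothiophen-2-yl also gives a 5.7-fold higher number from compound 3 to compound 4 (0.76 log units; beyond the scatter) rather than any recovery, while the comparison with 2,6-dichloropyridin-4-yl gives a 2.0-fold higher number from compound 2 to compound 4 (0.30 log units; within the scatter) so those two groups cannot be told apart. Of the four groups now seen here, only thiophen-2-yl gives a low number, and joining a six-membered aromatic ring of carbon only to that five-membered ring removes this advantage. Nothing shown here explains the rise.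

The compounds shown leave open whether the low number depends on the sulfur of thiophen-2-yl, which a furan-2-yl group would test, or on the ring remaining unfused, which a thiophen-2-yl ring carrying a single methyl group would begin to test. From the compounds shown here alone, it also remains open whether the same order of these groups would hold with a carboxylic acid in place of the ethoxycarbonyl group.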